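Benzylsulfanyl variation on the shared core: compound 4

The source may hold more compounds than are shown below. What is called first, only, known or untested is meant among the compounds shown, and "the series" means these compounds.

Measured so far in an assay on isolated protein for inhibition of Alpha glucosidase (Homo sapiens), read by spectrophotometry, with stated times of 15 min and 30 min; on this read-out higher numbers stand for weaker inhibition and lower numbers for stronger inhibition:
compound 1 `Fc1ccc(CSc2nc(-c3ccc(Br)cc3)cc(-c3ccc(Br)cc3)n2)cc1`: 19000 nM
compound 2 `Cc1ccc(-c2cc(-c3ccc(Br)cc3)nc(SCc3ccc(Cl)cc3)n2)cc1`: 19000 nM
compound 3 `Clc1ccccc1CSc1nc(-c2ccc(Br)cc2)cc(-c2ccc(Br)cc2)n1`: 19000 nM

Compound 3 stands level with compounds 1 and 2 in this assay at the digits shown; the three values sit together within the scatter, so no order among them can be read. Among the measured compounds shown here, the one measured step at the saturated chain carbon bound to a sulfur is no change at the digits printed from compound 1 to compound 3 (within the scatter), which leaves the read-out unchanged. Compound 2 differs from compound 3 in two places, so only its value is taken, and it too sits level.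

Compound 4 `Clc1ccc(CSc2nc(-c3ccc(Br)cc3)cc(-c3ccc(Br)cc3)n2)cc1` has not yet been measured. It differs from compound 3 by 4-chlorophenyl in place of 2-chlorophenyl on a saturated chain carbon bound to a sulfur. For the measured compounds named here, no measured step covers exactly this change; the only step at the same place, from compound 1 to compound 3, gave no change, and nothing among the three values points in either direction. The expected step in this assay is therefore no change at the digits printed from compound 3 to compound 4 (within the scatter), none beyond the scatter. Compound 4 is expected at 19000 nM in this assay, with a range from 9500 nM to 38000 nM.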

Compound 4, half-maximal inhibitory concentration: 19000 nM
The estimate for compound 4 equals the measured number at the digits printed; the range from low to high includes it.
By their numbers in this assay, from the lowest: compounds 1, 2, 3 and 4 (each within the scatter of the next).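

In this assay, 4-chlorophenyl in place of 2-chlorophenyl on a saturated chain carbon bound to a sulfur gives no change at the digits printed from compound 3 to compound 4 (within the scatter) and isolates the placing of the chloro from the identity of the halogen, which the earlier step at this position altered together. Chloro in place of fluoro on an aromatic carbon, now read alone, gives no change at the digits printed from compound 1 to compound 4 (within the scatter) and bromo in place of methyl on an aromatic carbon gives no change at the digits printed from compound 2 to compound 4 (within the scatter), so none of these three single exchanges shows a difference in this series. Nothing in the available evidence bears on this result.

The compounds shown all carry a halogen on the benzyl group. Going by these compounds, whether a carboxylic acid or an amine on that phenyl, or a longer chain in place of the benzyl group, would separate from these values remains open.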